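Replacing 4-(methylsulfonyl)phenyl in a small antiproliferative series

This account rests on a few compounds, and the source may have more. Where it says the series, first, only, none or still open, it means among the compounds named here.

In a functional assay on MCF7 cells (Homo sapiens) for antiproliferative activity, read by MTT assay, with stated times of 24 h and 72 h (on this read-out higher numbers stand for weaker inhibition and lower numbers for stronger inhibition), compound 1 (`COc1cc(N2C(=O)[C@@H](Oc3ccccc3)[C@H]2c2ccc3ccccc3c2)cc(OC)c1OC`) gives 282000 nM, compound 2 (`COc1cc(N2C(=O)[C@@H](Oc3ccccc3)[C@H]2c2cccc([N+](=O)[O-])c2)cc(OC)c1OC`) gives 30000 nM, and compound 3 (`COc1cc(N2C(=O)[C@@H](Oc3ccccc3)[C@H]2c2ccc(S(C)(=O)=O)cc2)cc(OC)c1OC`) gives 62000 nM, the second highest of the three numbers. Compound 4 (`COc1cc([C@@H]2[C@H](Oc3ccccc3)C(=O)N2c2cc(OC)c(OC)c(OC)c2)ccc1O`) keeps the shared core but carries 4-hydroxy-3-methoxyphenyl in place of 4-(methylsulfonyl)phenyl on a saturated ring carbon. Three measured steps change that same position, all of them modest: a 9.4-fold lower number from compound 1 to compound 2 (0.97 log units; beyond the scatter), a 4.5-fold lower number from compound 1 to compound 3 (0.66 log units; beyond the scatter) and a 2.1-fold higher number from compound 2 to compound 3 (0.32 log units; beyond the scatter). Going by the values given here, the last of these, a swap between two substituted phenyl groups, is the closest precedent. Among the compounds with values here, no measured compound carries a hydroxy group there, so the direction is uncertain. A modest step toward a lower number is expected in this assay, estimated as a 4.1-fold lower number from compound 3 to compound 4 (0.62 log units; beyond the scatter). For compound 4 the estimated value is 15000 nM, with an expected range from 2500 nM to 70000 nM.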

Compound 4, half-maximal inhibitory concentration: 32000 nM
Compound 4: middle estimate off by 2.1-fold (0.33 log units), on the low side, and the stated range covers the measured number.
By their numbers in this assay, from the lowest: compounds 2, 4 and 3 (each within the scatter of the next, the first and the last beyond it); then compound 1.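

Both a 1.9-fold lower number from compound 3 to compound 4 (0.29 log units; within the scatter) and a 1.1-fold higher number from compound 2 to compound 4 (0.03 log units; within the scatter) stay within the scatter in this assay once 4-hydroxy-3-methoxyphenyl enters, the first group shown at this position with a hydrogen-bond donor. Of the three new steps, only an 8.8-fold lower number from compound 1 to compound 4 (0.95 log units; beyond the scatter) lies beyond the scatter. No evidence is available to explain these results.

The compounds shown leave open whether the hydroxy or the methoxy group on this phenyl ring matters on its own. They also leave open how an amine or a carboxylic acid on that ring would read out.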